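The source may report more compounds than this note shows. Statements on the series, on what has been measured and on what is new or still open speak of the compounds shown alone.

Within the data shown here, compound 3, `CC(C)c1ccccc1NC(=O)N[C@H](C)c1ccccc1`, sits at the bottom of the three numbers measured so far: in an ADME assay on the whole organism with Oryza sativa as the target, tested at 10 uM (a lower number here means a stronger effect, a higher number a weaker effect of the compound at the concentration tested), compound 3 gives 17%. Its nearest neighbour in value is compound 2, `CCc1ccccc1NC(=O)N[C@@H](C)c1ccccc1`, which in this assay gives 95%, and the furthest is compound 1, `Cc1ccccc1NC(=O)N[C@@H](C)c1ccccc1`, which in this assay gives 99%; both of those gaps to compound 3 lie well beyond the scatter. Among the measured compounds shown here, the only measured step between two compounds that differ in one place is a number 4 percentage points lower from compound 1 to compound 2 (within the scatter).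

Compound 4 is `CC(C)c1ccccc1NC(=O)N[C@@H](C)c1ccccc1`. Compared with compound 3, (the two compounds have the same atoms and bonds and differ only in configuration as drawn: 1 of 1 stereo elements differ; a stereocentre at a saturated chain carbon is drawn R in compound 3 and S in compound 4). For the measured compounds named here, no measured step involves a change of configuration, so none of the existing data bears directly on this move, and the only step available, from compound 1 to compound 2, concerns a different kind of change. The expectation for compound 4 is therefore wide open in both directions, with a step of a number 38 percentage points higher from compound 3 to compound 4 (beyond the scatter) taken as the middle guess. Compound 4 is estimated at 55%, with a range from 15% to 98%.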

Compound 4, a percentage reported as activity, at one concentration (the size of the read-out at that concentration, not a potency): 93%
The estimate for compound 4 lay 38 percentage points below the measured number; measured number inside the range.
By their numbers in this assay, from the lowest: compound 3; then compounds 4, 2 and 1 (each within the scatter of the next).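

In this assay, among these compounds, the drawn configuration at the saturated chain carbon emerges as a change that can move the number far beyond the scatter, something no earlier step showed, with a number 76 percentage points higher from compound 3 to compound 4 (beyond the scatter). Nothing else separates this pair, so the whole gap traces to that one stereocentre: the fact that compounds 3 and 4 differ only in the configuration as drawn. With the configuration of compound 4 kept, changes to the chain on the aromatic carbon show nothing comparable: there is a number 6 percentage points lower from compound 1 to compound 4 (within the scatter) for isopropyl in place of methyl, and a number 2 percentage points lower from compound 2 to compound 4 (within the scatter) for methyl in place of hydrogen on the chain.

The compounds shown leave open whether the R configuration gives a low number only with isopropyl, or also with methyl or ethyl on the aromatic carbon. They also leave open how a methoxy group or a chlorine atom would behave in place of that chain.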